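The source may report more compounds than this note shows. Statements on the series, on what has been measured and on what is new or still open speak of the compounds shown alone.

Measured compounds:
- compound 1, `CC(C)COc1cccc(-c2ccc(C(=O)N(Cc3cccc(OCCCCCC(=O)O)c3)C(C)C)cc2)c1`. In an ADME assay on HEK293 cells (Homo sapiens) for cytotoxicity, read by CellTiter-Glo and resazurin assay, with a stated time of 72 h (a lower number here means that less compound is needed, a higher number that more compound is needed for the effect), compound 1 gives > 26000 nM, which is a limit of the assay and not a number.
- compound 2, `CC(C)N(Cc1cccc(OCCCCCC(=O)O)c1)C(=O)c1ccc(-c2ccc3c(c2)OCCO3)cc1`. In this assay compound 2 gives > 21900 nM, again a limit of the assay rather than a number.

For the measured compounds named here, compound 2 thus stands at a limit in this assay; the only other value shown, that of compound 1, is also a limit. Going by the values given here, the one step between measured compounds, a step that the two limits leave unreadable from compound 1 to compound 2, cannot be read in size or direction because the limit of > 21900 nM in this assay, at which 1 of the 2 values shown sits, and the limit of > 26000 nM in this assay, at which 1 of the 2 values shown sits, both sit at the ceiling of the measurement.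

Compound 3, `CC(C)N(Cc1cccc(OCCCCCC(=O)O)c1)C(=O)c1ccc(-c2c[nH]c3ccccc23)cc1`, differs from compound 2 by 1H-indol-3-yl in place of 2,3-dihydro-1,4-benzodioxin-6-yl on an aromatic carbon. Among the compounds with values here, no measured step gives a readable size for a change at this position, since the single step available is unreadable. With both neighbours at the limit, the step that the limit leaves unreadable from compound 2 to compound 3 is expected to stay within the usual scatter, with a limit again the most likely outcome. Compound 3 is therefore estimated at 25000 nM, with a range of 9000 nM to 60000 nM.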

Compound 3, half-maximal effective concentration: > 26000 nM
Compound 3 ended at the assay's limit; the forecaster's own chance of this, stated with the estimate: 70%; at least 1.0-fold (0.01 log units) between middle value and limit.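

In this assay compound 3 gives > 26000 nM, a limit of the assay and not a number. For the compounds shown here, no step among compound 1, compound 2 and compound 3 can be read in size or direction. Still open, going by these compounds, is whether 3-(isobutoxy)phenyl, 2,3-dihydro-1,4-benzodioxin-6-yl and 1H-indol-3-yl differ at all in this assay.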